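Replacing the acyl group of compound 2 to reach compound 4

The compounds below may be only part of what the source reports. "The series", "measured", "known", "first", "only" and "open" are said of these compounds alone.

Three compounds share a core carrying a piperazine amide and a branched amine. Compound 1 `CC(C)C[C@H](N)c1ccccc1N1CCN(C(=O)[C@H](C)Cc2ccc(Cl)cc2F)CC1` gives 67 nM in an assay on HEK293 cells for displacement of a labelled ligand from Melanocortin receptor 4 (Homo sapiens); on this read-out higher numbers stand for weaker inhibition and lower numbers for stronger inhibition; compound 3 `Cc1ccc(N2CCN(C(=O)[C@H](C)Cc3ccc(Cl)cc3F)CC2)c([C@@H](N)CC(C)C)c1`, which differs from it only by a 3.4-fold lower number from compound 1 to compound 3 (0.53 log units; beyond the scatter), gives 20 nM. Compound 2 `CC(C)C[C@H](N)c1cc(C(F)(F)F)ccc1N1CCN(C(=O)COc2ccc(Cl)cc2)CC1` gives 2900 nM, the highest of the three numbers, far above both compound 1 and compound 3.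

Compound 4 `CCOc1cccc(CC(C)C(=O)N2CCN(c3ccc(C(F)(F)F)cc3[C@@H](N)CC(C)C)CC2)c1` has not been measured. It differs from compound 2 as follows: 1-(3-ethoxybenzyl)ethyl in place of (4-chlorophenoxy)methyl on a carbonyl carbon. Among the compounds with values here, no measured step covers this change directly; the only measured step, from compound 1 to compound 3, concerns an aromatic methyl and says nothing about the acyl group. Within the data shown here, compound 1 and compound 3 do, however, carry an acyl group of the same general kind as the one that enters in compound 4, and both give much lower numbers than compound 2. On that basis a clear step downward is expected, a 12-fold lower number from compound 2 to compound 4 (1.06 log units; beyond the scatter). Compound 4 is therefore estimated at 250 nM, with a range from 50 nM to 1200 nM.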

Compound 4, inhibition constant: 2200 nM
Compound 4: middle estimate off by 8.8-fold (0.94 log units), on the low side; measured number outside the range, above it.
By their numbers in this assay, from the lowest: compound 3; then compound 1; then compounds 4 and 2 (each within the scatter of the next).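

Within the data shown here, on the core carrying trifluoromethyl, 1-(3-ethoxybenzyl)ethyl in place of (4-chlorophenoxy)methyl on a carbonyl carbon gives a 1.3-fold lower number from compound 2 to compound 4 (0.12 log units; within the scatter) in this assay, the first reading of a change at this position, and the two numbers cannot be told apart. The entering group alone therefore does not bring compound 4 into the range of compound 1 and compound 3, which each differ from compound 4 in more than one place. Nothing given here bears on why this exchange leaves the two numbers within the scatter.

Open, as far as these compounds go, is how the same exchange would read on the core of compound 1, which has no trifluoromethyl group. Also open, from the compounds shown here alone, is whether a nitrile or a longer alkoxy chain in place of the ethoxy group would shift the number.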